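Bromine Ortho to the Hydroxy Group of Compound 2

This account rests on a few compounds, and the source may have more. Where it says the series, first, only, none or still open, it means among the compounds named here.

Among the measured compounds shown here, compound 2 `COc1cc(/C=C2\CCC/C(=C\c3ccc([N+](=O)[O-])cc3)C2=O)ccc1O` gives 13.1 ug/mL in a functional assay on MDA-MB-231 cells (Homo sapiens) for cytotoxicity, read by MTT assay (a higher number here means a weaker inhibitor, a lower number a stronger inhibitor), the lowest of the two numbers measured so far; its nearest neighbour, compound 1 `COc1cccc(/C=C2\CCC/C(=C\c3ccc([N+](=O)[O-])cc3)C2=O)c1`, gives 51.4 ug/mL in this assay. For the measured compounds named here, the only measured step, a 3.9-fold lower number from compound 1 to compound 2 (0.59 log units; beyond the scatter), came from a hydroxy in place of hydrogen on an aromatic carbon. Compound 3 `COc1cc(/C=C2\CCC/C(=C\c3ccc([N+](=O)[O-])cc3)C2=O)cc(Br)c1O` has not yet been measured; it differs from compound 2 by bromo in place of hydrogen on an aromatic carbon, placed on the aromatic carbon ortho to the hydroxy group and meta to the methoxy group. Going by the values given here, no measured step involves a bromo group, so nothing bears directly on this change; the hydroxy step shows only that a change on this ring can move the number by a modest amount. The expected step of a 1.3-fold lower number from compound 2 to compound 3 (0.12 log units; within the scatter) is therefore kept small, likely within the scatter. The estimate for compound 3 is 10 ug/mL, within 4 ug/mL to 25 ug/mL.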

Compound 3, half-maximal inhibitory concentration: > 100 ug/mL
Compound 3 ended at the assay's limit; the forecaster's own chance of this, stated with the estimate: 5%; middle value at least 10-fold (1.00 log units) from the limit.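

Placed ortho to a hydroxy group and meta to a methoxy group, bromo in place of hydrogen on an aromatic carbon gives an at least 7.6-fold higher number from compound 2 to compound 3 (0.88 log units; beyond the scatter) in this assay. The hydroxy step had lowered the number on this ring, whereas this change raises it, so a single bromine atom at this carbon is enough to reverse the direction seen so far. The step is a bound and not a full size, because compound 3 sits at a limit of the assay and gives no number: the limit of > 100 ug/mL in this assay, at which 1 of the 3 values shown sits.

The compounds shown do not tell whether the rise belongs to bromine itself or to any group at this carbon; a fluoro, a methyl or an amine there would separate the two. They also leave open whether bromo would act the same way on a ring without the hydroxy group.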